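The source may hold more compounds than are shown below. What is called first, only, known or untested is meant among the compounds shown, and "the series" means these compounds.

In a functional assay on MCF7 cells (Homo sapiens) for inhibition, read by sulforhodamine B assay, with a stated time of 24 h (a lower number here means a stronger inhibitor, a higher number a weaker inhibitor), compound 3, `CC(=O)Nc1c(C#N)c(-c2ccccc2)cn1-c1ccc(S(=O)(=O)Nc2ccccn2)cc1`, gives 11800 nM, the highest of the three numbers recorded. Compound 1, `N#Cc1c(-c2ccccc2)cn(-c2ccc(S(=O)(=O)Nc3ccccn3)cc2)c1N`, gives 4600 nM, and compound 2, `CC(=O)Nc1c(C#N)c(-c2ccccc2)cn1-c1ccc(S(=O)(=O)Nc2nccs2)cc1`, gives 7240 nM. Two steps lead into compound 3: a 2.6-fold higher number from compound 1 to compound 3 (0.41 log units; beyond the scatter) and a 1.6-fold higher number from compound 2 to compound 3 (0.21 log units; within the scatter). Compound 4, `N#Cc1c(-c2ccccc2)cn(-c2ccc(S(=O)(=O)Nc3ccccn3)cc2)c1NC(=O)CCC(=O)O`, differs from compound 3 by carboxymethyl in place of hydrogen on a saturated chain carbon bound to a carbonyl carbon. Going by the values given here, no measured pair shows a change at this carbon, and the only step on the amide side, a 2.6-fold higher number from compound 1 to compound 3 (0.41 log units; beyond the scatter), moved the number modestly upward when the acetyl was introduced; a further extension of that acyl group is therefore expected to shift this assay little, perhaps a small rise. The number for compound 4 is estimated at 13000 nM, within 5500 nM to 32000 nM, a step of a 1.1-fold higher number from compound 3 to compound 4 (0.04 log units; within the scatter).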

Compound 4, half-maximal inhibitory concentration: 8320 nM
Estimate against measurement, compound 4: 1.6-fold (0.19 log units) above; measured number inside the range.
By their numbers in this assay, from the lowest: compounds 1, 2, 4 and 3 (each within the scatter of the next, the first and the last beyond it).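

In this assay, the carboxymethyl added at this saturated chain carbon gives a small step (a 1.4-fold lower number from compound 3 to compound 4 (0.15 log units; within the scatter)), so lengthening the acetyl to a chain ending in a carboxylic acid moves the number no further than the scatter. The whole (2-carboxyethyl)carbonyl group on the nitrogen also stays within the scatter (a 1.8-fold higher number from compound 1 to compound 4 (0.26 log units; within the scatter)), unlike the acetyl (a 2.6-fold higher number from compound 1 to compound 3 (0.41 log units; beyond the scatter)). Nothing available explains this result. The compounds shown leave open whether the acid itself matters, as a methyl ester or a primary amide at the chain end could show. As far as these compounds go, a longer chain ending in the same acid also remains untested here, as does a different sulfonamide partner such as 1,3-thiazol-2-yl on this acyl chain.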